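The source may report more compounds than this note shows. Statements on the series, on what has been measured and on what is new or still open speak of the compounds shown alone.

Compound 3 `COc1cc(-n2cnc3ccc(-c4cccc(O)c4)cc32)cc(OC)c1OC` gives 53 nM in a functional assay on SGC-7901 cells (Homo sapiens) for antiproliferative activity, read by MTT assay, with a stated time of 72 h (on this read-out higher numbers stand for weaker inhibition and lower numbers for stronger inhibition), the lowest of the two numbers in this small set. Compound 1 `COc1cc(-n2cnc3ccc(-c4cccc([N+](=O)[O-])c4)cc32)cc(OC)c1OC` gives 380 nM in this assay, so that a 7.2-fold lower number from compound 1 to compound 3 (0.86 log units; beyond the scatter). Compound 2 `COc1cc(-n2cnc3ccc(-c4ccc(Cl)cc4Cl)cc32)cc(OC)c1OC` reaches only > 10000 nM in this assay, which is a limit of the assay and not a number (the limit of > 10000 nM in this assay, at which 1 of the 3 values shown sits). Against that limit, an at least 180-fold lower number from compound 2 to compound 3 (2.27 log units; beyond the scatter).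

Compound 4 `COc1cc(-n2cnc3ccc(-c4cccc(Cl)c4)cc32)cc(OC)c1OC` differs from compound 3 in one place: chloro in place of hydroxy on an aromatic carbon. Among the measured compounds shown here, two measured steps bear on this change. Both steps into compound 3, a 7.2-fold lower number from compound 1 to compound 3 (0.86 log units; beyond the scatter) and an at least 180-fold lower number from compound 2 to compound 3 (2.27 log units; beyond the scatter), brought the hydroxy group in and lowered the number, so its removal is expected to raise the number. The step from compound 2 is only a loose guide, since compound 2 carries 2,4-dichlorophenyl rather than 3-chlorophenyl, and a single chloro is expected to weigh less than that. The expected step is therefore a 5.7-fold higher number from compound 3 to compound 4 (0.75 log units; beyond the scatter), a modest rise in this assay rather than a collapse to the limit. Compound 4 is estimated at 300 nM, with a range from 80 nM to 1500 nM.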

Compound 4, half-maximal inhibitory concentration: 1490 nM
Estimate against measurement, compound 4: 5.0-fold (0.70 log units) below; the range from low to high includes it.
By their numbers in this assay, from the lowest: compound 3; then compound 1; then compound 4. At a limit, above all of these: compound 2.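

With three groups now read at this one position in this assay, the numbers rise in the order hydroxy, nitro, chloro, as shown by a 28-fold higher number from compound 3 to compound 4 (1.45 log units; beyond the scatter) and by a 3.9-fold higher number from compound 1 to compound 4 (0.59 log units; beyond the scatter). The 3-chlorophenyl group still gives a measurable number, unlike 2,4-dichlorophenyl, with an at least 6.7-fold lower number from compound 2 to compound 4 (0.82 log units; beyond the scatter). Compound 2 remains at a limit of the assay, which is not a number: the limit of > 10000 nM in this assay, at which 1 of the 4 values shown sits.

The compounds shown leave open whether the low number of compound 3 depends on the hydroxy group itself or would also hold with an amine or a carboxylic acid in the same place. They also leave open how a hydroxy group would read elsewhere on this six-membered aromatic ring, and no cause for the rise from hydroxy to chloro can be read from these numbers.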